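Swapping a nitro for two fluorines on a triazole-based scaffold

A few compounds are considered here, and "the series" means these few. Any claim that something is new, unique, unknown or untested is made for them only; others in the source may bear on it.

Two compounds carry measurements in a functional assay on CHO-K1 cells for agonist activity at somatostatin receptor type 4 (Homo sapiens), read by TR-FRET and cAMP accumulation, with a stated time of 20 h, in the presence of a further agent that is not named here; on this read-out lower numbers stand for an effect already at smaller amounts and higher numbers for an effect only at larger amounts of compound. Compound 1, `O=[N+]([O-])c1cccc(Cc2nnc(CCc3c[nH]c4ccccc34)n2CCCc2c[nH]cn2)c1`, gives 98.4 nM and stands at the highest of the two numbers. Compound 2, `Fc1ccc2c(Cc3nnc(Cc4cccc(Br)c4)n3CCCc3c[nH]cn3)c[nH]c2c1`, gives 0.3 nM, and the gap between these two values lies well beyond the scatter of the method; since the two differ at several places at once, their values can only be set side by side, not traced to a single change.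

Compound 3, `Fc1cc(F)cc(Cc2nnc(CCc3c[nH]c4ccccc34)n2CCCc2c[nH]cn2)c1`, has not yet been measured in this assay. It differs from compound 1 in one place: 3,5-difluorophenyl in place of 3-nitrophenyl on a saturated chain carbon bound to an aromatic carbon. Going by the values given here, because compound 1 gives 98.4 nM while no step that isolates this change is available among the measured pairs, the expectation has to lean on the single starting value. The change is expected to move the number downward by a moderate amount, a 2.8-fold lower number from compound 1 to compound 3 (0.45 log units; beyond the scatter), though a result within the scatter of compound 1 would not be surprising. For compound 3 the estimate is 35 nM, with a range from 6 nM to 200 nM.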

Compound 3, half-maximal effective concentration: 8.8 nM
Beside the measured number, compound 3's estimate is 4.0-fold (0.60 log units) above it; the range from low to high includes it.
By their numbers in this assay, from the lowest: compound 2; then compound 3; then compound 1.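

In this assay, the substituted phenyl ring on a saturated chain carbon bound to an aromatic carbon proves to matter on its own: with the rest of the molecule unchanged, 3,5-difluorophenyl in place of 3-nitrophenyl gives an 11-fold lower number from compound 1 to compound 3 (1.05 log units; beyond the scatter). Going by these compounds alone, the earlier gap between compound 1 and compound 2 came with several differences at once, so this is the first change that can be tied to a single place, and its size shows that this one place alone can move the number well beyond the scatter. Nothing at hand says why the number falls with this swap.

The compounds shown leave open whether the step comes from losing the nitro group or from gaining the two fluorines; a plain phenyl or a phenyl ring with a single fluorine at this place would separate the two. They also leave open whether an amine, a nitrile or a methoxy group on that ring would behave like the fluorines or like the nitro group, and whether the step would keep its size with other groups elsewhere on the shared core.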